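This account rests on a few compounds, and the source may have more. Where it says the series, first, only, none or still open, it means among the compounds named here.

The measured compounds:
- compound 1, `O=C1C(N2CCCC2)=CC(=O)c2c1nc1n2[C@H]2OC[C@@H](O)[C@H]2OC1`: in a functional assay on MCF7 cells (Homo sapiens) for inhibition, read by sulforhodamine B assay (on this read-out lower numbers stand for stronger inhibition and higher numbers for weaker inhibition), compound 1 gives > 16000 nM, which is a limit of the assay rather than a number.
- compound 2, `O=C1C=C(Nc2cccc(Cl)c2)C(=O)c2c1nc1n2[C@H]2OC[C@@H](O)[C@H]2OC1`: compound 2 gives 4720 nM.
- compound 3, `O=C1C(Nc2cccc(Cl)c2)=CC(=O)c2c1nc1n2[C@H]2OC[C@@H](O)[C@H]2OC1`: compound 3 gives 2970 nM.

Compound 4, `O=C1C=C(N2CCCC2)C(=O)c2c1nc1n2[C@H]2OC[C@@H](O)[C@H]2OC1`, has not yet been measured in this assay. It differs from compound 2 by one change: pyrrolidin-1-yl in place of (3-chlorophenyl)amino on a double-bonded ring carbon. The same change, made on the other core, leads from compound 3 to compound 1: pyrrolidin-1-yl in place of (3-chlorophenyl)amino on a double-bonded ring carbon. The place is described in the same words for both pairs, so this is the same change, not merely the same kind. In this assay that change gave an at least 5.3-fold higher number from compound 3 to compound 1 (0.73 log units; beyond the scatter); the step can only be given as a lower bound because of the limit of > 16000 nM in this assay, at which 1 of the 3 values shown sits. The cores of compound 2 and compound 3 are built from the same atoms joined differently; the difference between the two cores is not broken down here. Compound 2 and compound 3 themselves give numbers within the usual scatter of each other, so nothing separates them.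

Starting from compound 2 at 4720 nM, a step of the size seen in an at least 5.3-fold higher number from compound 3 to compound 1 (0.73 log units; beyond the scatter) would carry compound 4 past the limit of the assay. For compound 4 the expected value is therefore 25000 nM, estimated to lie between 8000 nM and 80000 nM. This estimate means a step of a 5.3-fold higher number from compound 2 to compound 4 (0.72 log units; beyond the scatter), and a limit rather than a number seems the likelier outcome. The expectation rests on one precedent only, an at least 5.3-fold higher number from compound 3 to compound 1 (0.73 log units; beyond the scatter), so it is loose.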

Compound 4, half-maximal inhibitory concentration: > 16000 nM
Compound 4 was reported as a limit; the forecaster's own chance of this, stated with the estimate: 70%; the middle value does not contradict the limit.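

In this assay, putting pyrrolidin-1-yl in place of (3-chlorophenyl)amino gives an at least 3.3-fold higher number from compound 2 to compound 4 (0.53 log units; beyond the scatter), so the swap that weakened inhibition on the core of compound 3 also weakens it on the core of compound 2. Compound 4 gives > 16000 nM, which is a limit of the assay and not a number. The direction of the change therefore carries over from one core to the other, but its true size is unknown on both cores, and the data cannot show whether the two cores respond equally: the same change on two cores in this assay, an at least 5.3-fold higher number (0.73 log units; beyond the scatter) from compound 3 to compound 1 and an at least 3.3-fold higher number (0.53 log units; beyond the scatter) from compound 2 to compound 4; the limit leaves it open whether they differ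

With only these two groups at this place, the compounds shown do not reveal which part of the difference between them matters, whether the chlorine, the six-membered aromatic ring of carbon only or the hydrogen on the linking nitrogen. Plain phenylamino, benzylamino, an open-chain amine such as dimethylamino and a ring amine such as morpholin-4-yl could help separate these parts, and would show whether any group without the aromatic ring keeps a measurable value on either core.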